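Indazole series notes: aminopyrimidine in place of oxazole

A few compounds are considered here, and "the series" means these few. Any claim that something is new, unique, unknown or untested is made for them only; others in the source may bear on it.

Measured so far:
compound 1 `OCc1ccc(-c2nn(Cc3cncnc3)c3ccccc23)o1`, 3200 nM
compound 2 `Cc1coc(-c2nn(Cc3ccccc3F)c3ncccc23)n1`, 1200 nM

In a functional assay (aorta) with Oryctolagus cuniculus as the target (on this read-out higher numbers stand for weaker inhibition and lower numbers for stronger inhibition), compound 2 gives 1200 nM, the lowest of the two numbers; the other number, that of compound 1 at 3200 nM, stands beyond the scatter above it. Compound 3 `Cc1cnc(-c2nn(Cc3ccccc3F)c3ncccc23)nc1N` differs from compound 2 by 4-amino-5-methylpyrimidin-2-yl in place of 4-methyl-1,3-oxazol-2-yl on an aromatic carbon. Within the data shown here, no pair of measured compounds shows a change of this kind, so the series offers no step to lean on. The expected step is a 1.2-fold lower number from compound 2 to compound 3 (0.08 log units; within the scatter), none beyond the scatter in either direction. For compound 3 the estimate in this assay is 1000 nM, with a range from 300 nM to 4000 nM.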

Compound 3, half-maximal inhibitory concentration: 675000 nM
For compound 3 the middle estimate is 680-fold (2.83 log units) below the measured one; measured number outside the range, above it.
By their numbers in this assay, from the lowest: compound 2; then compound 1; then compound 3.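

In this assay, the substituent on this aromatic carbon of the five-membered aromatic ring strongly affects the read-out: 4-amino-5-methylpyrimidin-2-yl in place of 4-methyl-1,3-oxazol-2-yl gives a 560-fold higher number from compound 2 to compound 3 (2.75 log units; beyond the scatter). Among these compounds, this is the first single-place step, and it shows that the two heteroaryl groups are not interchangeable here. No measurement available explains the size of this step.

Going by these compounds, the change alters the ring and adds an amine at once, so their separate contributions remain open. A 5-methylpyrimidin-2-yl group, which lacks the amine, would separate them.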